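The compounds below may be only part of what the source reports. "The series", "measured", "known", "first", "only" and "open" are said of these compounds alone.

Compound 1 `CC(=O)N1CCc2c(c(-c3ccc(C(F)(F)F)cc3)nn2CC(O)CN2CCC(n3c(O)nc4ccccc43)CC2)C1`: 100 nM
Compound 2 `CS(=O)(=O)N1CCc2c(c(-c3ccc(C(F)(F)F)cc3)nn2CC(O)CN2CCC(n3c(O)nc4ccccc43)CC2)C1`: 50 nM

In an assay on isolated protein for inhibition of cathepsin S (Homo sapiens) (on this read-out higher numbers stand for weaker inhibition and lower numbers for stronger inhibition), compound 2 gives 50 nM. Within the data shown here, its only neighbour is compound 1, which gives 100 nM; the step of a 2.0-fold lower number from compound 1 to compound 2 (0.30 log units; within the scatter) is within the scatter, so the two stand together. Compound 3 `Cn1c(=O)n(C2CCN(CC(O)Cn3nc(-c4ccc(C(F)(F)F)cc4)c4c3CCN(S(C)(=O)=O)C4)CC2)c2cc(Cl)ccc21` differs from compound 2 by a group of 12 heavy atoms (8 carbon, 2 nitrogen, 1 oxygen, 1 chlorine; one five-membered aromatic ring with 2 hetero atoms, one six-membered aromatic ring of carbon only) in place of a group of 10 heavy atoms (7 carbon, 2 nitrogen, 1 oxygen; one five-membered aromatic ring with 2 hetero atoms, one six-membered aromatic ring of carbon only), on a saturated ring carbon. Among the measured compounds shown here, no measured step touches this part of the molecule: the single measured step, a 2.0-fold lower number from compound 1 to compound 2 (0.30 log units; within the scatter), concerns the amine nitrogen in a ring and gives no guide to direction here. Compound 3 is therefore expected near compound 2, with a wide range, at 70 nM (15 nM to 400 nM). The expected step is a 1.4-fold higher number from compound 2 to compound 3 (0.15 log units; within the scatter).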

Compound 3, half-maximal inhibitory concentration: 80 nM
Compound 3: the middle estimate sits 1.1-fold (0.06 log units) below what was measured; measured number inside the range.
By their numbers in this assay, from the lowest: compounds 2, 3 and 1 (each within the scatter of the next).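

Among these compounds, the earlier step concerned only the amine nitrogen in a ring, whereas this one is the first to touch the saturated ring carbon, where a group with a chlorine and 0 hydrogen-bond donors replaces 2-hydroxy-1H-benzimidazol-1-yl, which has 1 hydrogen-bond donor. The change gives a 1.6-fold higher number from compound 2 to compound 3 (0.20 log units; within the scatter), so this position accepts the larger group without a change beyond the scatter. No available evidence bears on this result.

Going by these compounds, the separate contributions of the chlorine and the other differences in the group remain open. So does the outcome with a simple amine or a carboxylic acid on this ring carbon.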